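This account rests on a few compounds, and the source may have more. Where it says the series, first, only, none or still open, it means among the compounds named here.

Compound 1 `COc1ccc(-c2cc3c(OC)cc(OC)cc3n(C)c2=O)cc1` is the starting point. In a functional assay on A549 cells (Homo sapiens) for cytotoxicity, read by colorimetric assay and MTT assay (on this read-out lower numbers stand for stronger inhibition and higher numbers for weaker inhibition), compound 1 gives 10000 nM. Two related compounds carry a larger group on the saturated chain carbon bound to the aromatic nitrogen: compound 2 `COc1ccc(-c2cc3c(OC)cc(OC)cc3n(CC(=O)OCc3ccccc3)c2=O)cc1`, which in this assay gives 10000 nM, and compound 3 `COc1ccc(-c2cc3c(OC)cc(OC)cc3n(CCC(=O)OCc3ccccc3)c2=O)cc1`, which in this assay gives 10000 nM. The steps among these three are flat: no change at the digits printed from compound 1 to compound 2 (within the scatter), no change at the digits printed from compound 1 to compound 3 (within the scatter) and no change at the digits printed from compound 2 to compound 3 (within the scatter). On the numbers shown, compound 1 therefore stands level with compounds 2 and 3.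

Compound 4 `COc1cc(OC)c2cc(-c3ccc(O)cc3)c(=O)n(C)c2c1` has not been measured. It differs from compound 1 at a different place altogether: hydrogen in place of methyl on an oxygen on an aromatic ring. Within the data shown here, none of the measured steps touches this oxygen; all three alter only the group on the nitrogen, and each of them left the read-out unmoved. Among the measured compounds shown here, there is thus no measured step that argues for a shift in either direction, and the only guide is that every change made so far to the shared core has left the value where it was. Compound 4 is accordingly expected to give about 10000 nM in this assay, within an expected range from 3000 nM to 30000 nM. The step this estimate implies is no change at the digits printed from compound 1 to compound 4 (within the scatter), which is expected to lie within the scatter.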

Compound 4, half-maximal inhibitory concentration: 10000 nM
Compound 4: the middle estimate sits on the measured number at the digits printed; the measured number falls inside the stated range.
By their numbers in this assay, from the lowest: compounds 1, 2, 3 and 4 (each within the scatter of the next).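

In this assay, putting hydrogen in place of methyl on this oxygen on an aromatic ring, which turns 4-methoxyphenyl into 4-hydroxyphenyl, gives no change at the digits printed from compound 1 to compound 4 (within the scatter). The earlier compounds shown here differed only in the group on the nitrogen. Among these compounds, this step is the first measured at a second place on the molecule, and this place is flat as well for this one change. No separate measurement bears on this result, so the data offer no explanation for the unchanged value.

All four compounds share one printed value, so the compounds shown do not reveal any change that makes the number lower or higher, and they do not show which parts of the molecule can affect it. It remains open whether a longer chain such as ethyl on this oxygen, an amine in place of the hydroxy group, or a carboxylic acid in place of the benzyl ester on the nitrogen chain would move the value, and the other methoxy groups on the shared core are also untested in the compounds shown here.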